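The compounds below may be only part of what the source reports. "The series", "measured", "known", "first", "only" and "open" are said of these compounds alone.

Compound 1 `CC(CCCC(=O)O)c1cccc(OCc2ccc3ccccc3n2)c1` is one of three compounds sharing a core and differing only in the side chain. In a functional assay (lung) for inhibition, with Cavia porcellus as the target (a higher number here means a weaker inhibitor, a lower number a stronger inhibitor), compound 1 gives 500 nM, the highest of the three numbers. Compound 2 `O=C(O)CCCCc1cccc(OCc2ccc3ccccc3n2)c1` gives 370 nM, and compound 3 `CC(CCCc1cccc(OCc2ccc3ccccc3n2)c1)C(=O)O` gives 75 nM. The measured steps were a 1.4-fold lower number from compound 1 to compound 2 (0.13 log units; within the scatter), a 6.7-fold lower number from compound 1 to compound 3 (0.82 log units; beyond the scatter) and a 4.9-fold lower number from compound 2 to compound 3 (0.69 log units; beyond the scatter); each of them moves a methyl along the chain, and none touches the acid end. Compound 4 `CC(CCCc1nnn[nH]1)c1cccc(OCc2ccc3ccccc3n2)c1` differs from compound 1 in one place: 1H-tetrazol-5-yl in place of carboxy on a saturated chain carbon, four bonds along the chain from an aromatic carbon. Within the data shown here, no measured step bears on this change, so the expectation for compound 4 is a step no larger than the scatter, no change at the digits printed from compound 1 to compound 4 (within the scatter), with a wide range. Compound 4 is expected to give 500 nM, between 150 nM and 1700 nM.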

Compound 4, half-maximal inhibitory concentration: 250 nM
The estimate for compound 4 lay 2.0-fold (0.30 log units) above the measured number; low and high end bracket the measured number.
By their numbers in this assay, from the lowest: compound 3; then compounds 4, 2 and 1 (each within the scatter of the next).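

The earlier steps shown here only moved a methyl along the chain, whereas this one replaces the acid end itself. In this assay, putting 1H-tetrazol-5-yl in place of carboxy gives a 2.0-fold lower number from compound 1 to compound 4 (0.30 log units; within the scatter), so on this chain the five-membered aromatic ring can stand in for carboxy without a difference that exceeds the scatter. No measurement here explains why the two groups read alike.

Going by these compounds, whether 1H-tetrazol-5-yl would read the same on the side chain of compound 3 stays open. So does how a primary amide or an acylsulfonamide would read in the same place.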